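Series notes: methyl on the outer phenyl of compound 3

This account rests on a few compounds, and the source may have more. Where it says the series, first, only, none or still open, it means among the compounds named here.

In a functional assay on B16-F10 cells (Mus musculus) for inhibition, read by colorimetric assay and MTT assay, with a stated time of 72 h (a lower number here means a stronger inhibitor, a higher number a weaker inhibitor), compound 1 `Cc1ccc(-c2cc(Nc3nnc(-c4ccc(C)cc4)s3)cs2)cc1` gives "not determined" (no result reported), and compound 2 `COc1ccc(-c2nnc(Nc3csc(-c4ccc(C)cc4)c3)s2)cc1` gives "not determined" (no result reported): neither has a reported result. Going by the values given here, compound 3 `Oc1ccc(-c2nnc(Nc3csc(-c4ccccc4)c3)s2)cc1` is the only member with a number; in this assay compound 3 gives 8000 nM. Compound 4 `Cc1ccc(-c2cc(Nc3nnc(-c4ccc(O)cc4)s3)cs2)cc1` differs from compound 3 by methyl in place of hydrogen on an aromatic carbon, para to a large group. Among the compounds with values here, no step between two measured compounds is available to show what such a change does. The entering group brings no ring, no donor and no acceptor; the expectation for this assay is a change that stays within the usual scatter, in no set direction. The estimated step from compound 3 to compound 4 is no change at the digits printed from compound 3 to compound 4 (within the scatter). Compound 4 is therefore estimated at 8000 nM, expected to lie between 3000 nM and 20000 nM.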

Compound 4, half-maximal inhibitory concentration: 6000 nM
Estimate against measurement, compound 4: 1.3-fold (0.12 log units) above; the measured number falls inside the stated range.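

Going by these compounds alone, with methyl in place of hydrogen on an aromatic carbon, para to a large group, this assay shows a 1.3-fold lower number from compound 3 to compound 4 (0.12 log units; within the scatter) and thus gives the first readable step. On this evidence, phenyl to 4-methylphenyl does not separate compound 4 from compound 3. No available evidence bears on the reason for this result.

On these data alone, whether an amine or a carboxylic acid at the same place would give a step beyond the scatter remains open. The same applies to a longer chain such as propyl.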